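One Aryl Swap on a Shared Core, One Expectation

The source may hold more compounds than are shown below. What is called first, only, known or untested is meant among the compounds shown, and "the series" means these compounds.

Measured compounds:
- compound 1, `COc1cccc(CNc2ncnc3c2ncn3[C@@H]2O[C@H](CO)[C@@H](O)[C@H]2O)c1`, gives 4900 nM in a functional assay on HL-60 cells (Homo sapiens) for antiproliferative activity, with a stated time of 72 h; a lower number here means a stronger inhibitor, a higher number a weaker inhibitor
- compound 2, `COc1ccc(CNc2ncnc3c2ncn3[C@@H]2O[C@H](CO)[C@@H](O)[C@H]2O)c(OC)c1`, gives 39000 nM in this assay

Compound 2 stands with the highest of the two numbers in this assay; its nearest neighbour is compound 1, and the step of an 8.0-fold higher number from compound 1 to compound 2 (0.90 log units; beyond the scatter) lies beyond the scatter. The unmeasured compound 3, `Cc1cccc(CNc2ncnc3c2ncn3[C@@H]2O[C@H](CO)[C@@H](O)[C@H]2O)c1O`, keeps the shared core and changes only the aryl group: 2-hydroxy-3-methylphenyl in place of 2,4-dimethoxyphenyl on a saturated chain carbon bound to a nitrogen on an aromatic ring.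

Going by the values given here, only one measured step bears on this change, the one from compound 1 to compound 2, where the aryl group went from 3-methoxyphenyl to 2,4-dimethoxyphenyl and the number rose an 8.0-fold higher number from compound 1 to compound 2 (0.90 log units; beyond the scatter). Compound 3 again carries a smaller aryl group than compound 2, with one hydrogen-bond donor and one acceptor instead of two acceptors. Among the compounds with values here, the data hold no analogue of 2-hydroxy-3-methylphenyl, so the expectation rests on the single step available. Compound 3 is therefore expected to give a lower number than compound 2, by about a 3.3-fold lower number from compound 2 to compound 3 (0.51 log units; beyond the scatter), with the shift resting on the step of an 8.0-fold higher number from compound 1 to compound 2 (0.90 log units; beyond the scatter). The estimate for compound 3 in this assay is 12000 nM, with a range from 3000 nM to 45000 nM.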

Compound 3, half-maximal inhibitory concentration: 15000 nM
Compound 3: the middle estimate sits 1.3-fold (0.10 log units) below what was measured, and the stated range covers the measured number.
By their numbers in this assay, from the lowest: compound 1; then compound 3; then compound 2.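

In this assay, 2-hydroxy-3-methylphenyl in place of 2,4-dimethoxyphenyl on a saturated chain carbon bound to a nitrogen on an aromatic ring gives a 2.6-fold lower number from compound 2 to compound 3 (0.41 log units; beyond the scatter) and so shows that the number at this position can also fall from the level of compound 2, here with an aryl group that carries a hydroxy group. The same group does not reach the level of compound 1, since replacing 3-methoxyphenyl with 2-hydroxy-3-methylphenyl gives a 3.1-fold higher number from compound 1 to compound 3 (0.49 log units; beyond the scatter) and leaves 3-methoxyphenyl with the lowest number of the three aryl groups. Nothing measured here accounts for either shift.

The compounds shown leave open whether the hydroxy group or the methyl group of compound 3 drives its step, as the two always appear together on the aryl ring. They also leave open how this position would respond to an aryl group bearing an amine or a carboxylic acid, or to a longer chain between the aryl group and the nitrogen.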